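A few compounds are considered here, and "the series" means these few. Any claim that something is new, unique, unknown or untested is made for them only; others in the source may bear on it.

Measured so far in a functional assay on NCI-H460 cells (Homo sapiens) for antiproliferative activity, with a stated time of 72 h; a lower number here means a stronger inhibitor, a higher number a weaker inhibitor:
- compound 1 (`Nc1ncnn2c([C@@H]3O[C@H](CO)[C@@H](O)[C@H]3O)cc(C#Cc3ccc(F)cc3)c12`) gives 79400 nM
- compound 2 (`Nc1ncnn2c([C@@H]3O[C@H](CO)[C@@H](O)[C@H]3O)cc(C#Cc3ccccc3)c12`) gives 38500 nM
- compound 3 (`COc1ccc(-c2cc([C@@H]3O[C@H](CO)[C@@H](O)[C@H]3O)n3ncnc(N)c23)cc1`) gives 69300 nM

Compound 3 (69300 nM) cannot be told apart from either of the other two compounds. Both of its steps lie within the scatter (a 1.1-fold lower number from compound 1 to compound 3 (0.06 log units; within the scatter)) and (a 1.8-fold higher number from compound 2 to compound 3 (0.26 log units; within the scatter)). Within the data shown here, only one step in the set goes beyond the scatter, and it is modest: the exchange of fluoro for hydrogen (a 2.1-fold lower number from compound 1 to compound 2 (0.31 log units; beyond the scatter)).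

The next compound is compound 4 (`Nc1ncnn2c([C@@H]3O[C@H](CO)[C@@H](O)[C@H]3O)cc(-c3ccccc3Cl)c12`), which has 2-chlorophenyl in place of 4-methoxyphenyl on an aromatic carbon. Among the measured compounds shown here, no measured compound carries a 2-chlorophenyl group, so no step tests this change directly. The closest evidence is the two exchanges at this same carbon, from 2-(4-fluorophenyl)ethynyl (a 1.1-fold lower number from compound 1 to compound 3 (0.06 log units; within the scatter)) and from 2-phenylethynyl (a 1.8-fold higher number from compound 2 to compound 3 (0.26 log units; within the scatter)). Neither moved the number beyond the scatter, although the groups differ considerably. From the compounds shown here alone, no step beyond the scatter is therefore expected here, and the direction remains open. The estimated step is small (a 1.4-fold lower number from compound 3 to compound 4 (0.14 log units; within the scatter)). For compound 4 the expected value is 50000 nM, within an estimated range from 20000 nM to 100000 nM.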

Compound 4, half-maximal inhibitory concentration: > 100000 nM
Compound 4: only a limit was reported; the forecaster's own chance of this, stated with the estimate: 15%; middle value at least 2.0-fold (0.30 log units) away from the limit.
By their numbers in this assay, from the lowest: compounds 2, 3 and 1 (each within the scatter of the next, the first and the last beyond it). At a limit, above all of these: compound 4.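

In this assay compound 4 is reported only as a limit, > 100000 nM, and not as a number, the only such value in the set: the limit of > 100000 nM in this assay, at which 1 of the 4 values shown sits.

Among these compounds, at this aromatic carbon, 2-chlorophenyl in place of 2-phenylethynyl gives the first exchange of the aryl or arylethynyl group that goes beyond the scatter (an at least 2.5-fold higher number from compound 2 to compound 4 (0.41 log units; beyond the scatter)), so the position is no longer one where every exchange stays within it. The floors of the other two steps, an at least 1.4-fold higher number from compound 3 to compound 4 (0.15 log units; that floor lies within the scatter) and an at least 1.2-fold higher number from compound 1 to compound 4 (0.10 log units; that floor lies within the scatter), lie within the scatter, so these steps show no separation, and their true size stays unread.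

The compounds shown do not settle whether the chloro substituent or the directly attached aryl ring goes with the change from compound 2, and a plain phenyl at this carbon would separate the two. Also open, from the compounds shown here alone, is whether a group of another kind here, such as an amine or a carboxylic acid, or a change to the 3,4-dihydroxy-5-(hydroxymethyl)oxolan-2-yl group, which all four compounds share, would move the number beyond the scatter.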